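The compounds below may be only part of what the source reports. "The series", "measured", "known", "first", "only" and "open" are said of these compounds alone.

Compound 1, `COc1ccc(C(=O)/C=C/c2cc(O)nc(O)n2)cc1`, and compound 2, `C[S+]([O-])c1cn([C@H]2C[C@H](O)[C@@H](CO)O2)c(=O)[nH]c1=O`, share nothing beyond the pyrimidine-derived fragment each carries; compound 2 bears a deoxyribose-type sugar on its ring, while compound 1 carries an enone linked to a methoxyphenyl group. In an ADME assay on L1210/0 cells (Mus musculus) for cytotoxicity, with a stated time of 48 h (on this read-out higher numbers stand for weaker inhibition and lower numbers for stronger inhibition), compound 1 gives > 200000 nM, which is a limit of the assay and not a number. In this assay compound 2 also gives > 200000 nM, again a limit rather than a measured value. Compound 2 therefore stands at the limit of > 200000 nM in this assay, at which 2 of the 2 values shown sit, so no ordering between the two compounds can be drawn from these figures.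

Compound 3, `CCCCC#Cc1cn([C@H]2C[C@H](O)[C@@H](CO)O2)c(=O)[nH]c1=O`, keeps the sugar and core of compound 2 and differs only at one ring carbon: a group of 6 heavy atoms (6 carbon; no ring) in place of a group of 3 heavy atoms (1 carbon, 1 oxygen, 1 sulfur; no ring), on an aromatic carbon. For the measured compounds named here, no measured step exists for any such change here, so the expectation rests on the limit alone. For compound 3 in this assay a move toward stronger inhibition is tentatively expected, with the step of an at least 3.3-fold lower number from compound 2 to compound 3 (0.52 log units; beyond the scatter), since a hex-1-yn-1-yl group in place of the sulfur-bearing substituent may shift the value below the limit. Compound 3 is accordingly estimated at 60000 nM, within a range from 5000 nM to 300000 nM.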

Compound 3, half-maximal inhibitory concentration: > 200000 nM
Compound 3 ended at the assay's limit; the forecaster's own chance of this, stated with the estimate: 45%; middle value at least 3.3-fold (0.52 log units) from the limit.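

For the compounds shown here, compound 3, like compound 2, sits at a limit of this assay and not at a number, so no step from compound 2 to compound 3 can be read. The compounds shown leave open how strongly any of them inhibits these cells, and whether a change at this ring carbon alters that at all: the limit of > 200000 nM in this assay, at which 3 of the 3 values shown sit.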